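Swapping one amino group on compound 2

This account rests on a few compounds, and the source may have more. Where it says the series, first, only, none or still open, it means among the compounds named here.

Of the compounds shown here, three sharing a core have been tested in an ADME assay on the whole organism for inhibition, with Echinochloa crus-galli var. formosensis as the target, with a stated time of 4 days; a lower number here means a stronger inhibitor, a higher number a weaker inhibitor. Compound 1 (`CCN(CC)c1nc(Cl)nc(NC(C)c2ccccc2)n1`) gives 1510 nM, compound 2 (`CCCN(CC)c1nc(Cl)nc(N[C@@H](C)c2ccccc2)n1`) gives 282 nM, and compound 3 (`CCCN(C)c1nc(Cl)nc(N[C@H](C)c2ccccc2)n1`) gives 9770 nM. Compound 2 has the lowest number of the three, and both gaps to it lie beyond the usual scatter, making it the strongest inhibitor so far.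

Compound 4 (`CC[C@@H](C)Nc1nc(Cl)nc(N[C@@H](C)c2ccccc2)n1`) keeps the rest of compound 2 but carries (sec-butyl)amino in place of ethyl(propyl)amino on an aromatic carbon. Going by the values given here, no measured pair isolates this change, and none of the tested compounds carries this group, so any forecast is loose. Compound 2 sits at the low end of the set at 282 nM, and a new group is therefore more likely to raise the number than to lower it. The expected change is a 1.8-fold higher number from compound 2 to compound 4 (0.25 log units; within the scatter), a moderately weaker result that may not clear the scatter. For compound 4 the estimated value is 500 nM, with an expected range of 90 nM to 2800 nM.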

Compound 4, half-maximal inhibitory concentration: 7410 nM
For compound 4 the middle estimate is 15-fold (1.17 log units) below the measured one, outside the stated range (above it).
By their numbers in this assay, from the lowest: compound 2; then compound 1; then compounds 4 and 3 (each within the scatter of the next).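

In this assay, replacing ethyl(propyl)amino with (sec-butyl)amino on this aromatic carbon gives a 26-fold higher number from compound 2 to compound 4 (1.42 log units; beyond the scatter), so this position responds strongly to which amino group it carries. Going by these compounds alone, this is the first measured pair that differs only here, and the change makes compound 4 a much weaker inhibitor than compound 2. The swap alters several things at once, adding a hydrogen-bond donor and a defined stereocentre while also changing the chain, and no measurement here explains the loss.

Which of these differences drives the step remains open. A methyl(sec-butyl)amino group would keep the branched chain without the amino hydrogen, while a straight butylamino chain would keep that hydrogen without the branch, so each could help separate the two.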